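Replacing pyridin-2-yl with 3-ethynylphenyl in the series

The compounds below may be only part of what the source reports. "The series", "measured", "known", "first", "only" and "open" are said of these compounds alone.

compound 1 (`COc1ccc(F)cc1N1C(=O)CSC1c1cccc(C(=O)NCCCCc2ccccc2)c1`): 1250 mL.min-1.g-1
compound 2 (`Cc1cccc(N2C(=O)CSC2c2cccc(C(=O)NCCCCc3ccccc3)c2)c1`): 2550 mL.min-1.g-1
compound 3 (`O=C(NCCCCc1ccccc1)c1cccc(C2SCC(=O)N2c2ccccn2)c1`): 412 mL.min-1.g-1

In an ADME assay on microsomes from liver (Homo sapiens) for metabolic stability, read by LC-MS, using NADPH, with a stated time of 10 min, tested at 0.1 uM (on this read-out lower numbers stand for slow clearance and higher numbers for fast clearance), compound 3 gives the lowest of the three numbers, 412 mL.min-1.g-1, beyond the scatter from both others. Compound 4 (`C#Cc1cccc(N2C(=O)CSC2c2cccc(C(=O)NCCCCc3ccccc3)c2)c1`) differs from it as follows: 3-ethynylphenyl in place of pyridin-2-yl on an amide-type nitrogen in a ring. Two measured steps at this same place bear on the change: a 3.0-fold lower number from compound 1 to compound 3 (0.48 log units; beyond the scatter) and a 6.2-fold lower number from compound 2 to compound 3 (0.79 log units; beyond the scatter). Both arrive at pyridin-2-yl with a lower number, so leaving that group should raise it. Compound 2, with 3-methylphenyl at this place, gives 2550 mL.min-1.g-1 and is the closest reference. The expected change is a 4.4-fold higher number from compound 3 to compound 4 (0.64 log units; beyond the scatter), which would lie beyond the scatter. For compound 4 the estimated value is 1800 mL.min-1.g-1, with an expected range from 750 mL.min-1.g-1 to 4200 mL.min-1.g-1.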

Compound 4, intrinsic clearance in microsomes: 751 mL.min-1.g-1
Compound 4: middle estimate off by 2.4-fold (0.38 log units), on the high side, within the range that was stated.
By their numbers in this assay, from the lowest: compounds 3, 4 and 1 (each within the scatter of the next, the first and the last beyond it); then compound 2.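

In this assay, ethynyl in place of methyl on an aromatic carbon is a clear change at this position (a 3.4-fold lower number from compound 2 to compound 4 (0.53 log units; beyond the scatter)), so the ring substituent matters, not only the ring type. Yet the carbon-only ring of compound 4 stays within the scatter of pyridin-2-yl (a 1.8-fold higher number from compound 3 to compound 4 (0.26 log units; within the scatter)) and of 5-fluoro-2-methoxyphenyl (a 1.7-fold lower number from compound 1 to compound 4 (0.22 log units; within the scatter)), so a carbon-only ring does not by itself separate from pyridin-2-yl; compound 2 goes against this. Nothing available explains these steps. Open, from the compounds shown here alone, is whether the ethynyl step carries over to a pyridin-2-yl ring. Also open, going by these compounds, is how a carboxylic acid or an amine at this place would read.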